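Removing a Trifluoromethyl Group in a Triazene Cytotoxicity Series

The source may hold more compounds than are shown below. What is called first, only, known or untested is meant among the compounds shown, and "the series" means these compounds.

Compound 1 `Fc1ccc(F)c(/N=N/Nc2ccccc2)c1` and compound 2 `Fc1ccc(F)c(/N=N/Nc2cccc(C(F)(F)F)c2)c1` share one core, while compound 3 `CN(C)CCCN(/N=N/c1ccccc1)c1cccc(C(F)(F)F)c1` is built on another; the difference between the two cores is not broken down here. In an ADME assay on MDBK cells (Bos taurus) for cytotoxicity, read by MTT assay, with a stated time of 96 h (a lower number here means that less compound is tolerated, a higher number that more compound is tolerated), compound 1 gives > 100000 nM, which is a limit of the assay rather than a number. In this assay compound 2 likewise gives > 100000 nM, again a limit. Among the compounds with values here, compound 3 is the only member of the set with a measured number: in this assay compound 3 gives 38000 nM.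

The change from compound 2 to compound 1 is hydrogen in place of trifluoromethyl on an aromatic carbon, and it produces a step that the two limits leave unreadable from compound 2 to compound 1 because of the limit of > 100000 nM in this assay, at which 2 of the 3 values shown sit. Compound 4 `CN(C)CCCN(/N=N/c1ccccc1)c1ccccc1` has not yet been measured; it differs from compound 3 by hydrogen in place of trifluoromethyl on an aromatic carbon, the same change at the same kind of place. Because compound 3 gives 38000 nM and the measured pair sets no readable size, the expected step is modest: a 1.3-fold higher number from compound 3 to compound 4 (0.12 log units; within the scatter). Compound 4 is therefore estimated at 50000 nM, with a likely range from 20000 nM to 140000 nM.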

Compound 4, half-maximal cytotoxic concentration: 95000 nM
Beside the measured number, compound 4's estimate is 1.9-fold (0.28 log units) below it, and the stated range covers the measured number.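

In this assay, hydrogen in place of trifluoromethyl on an aromatic carbon gives a 2.5-fold higher number from compound 3 to compound 4 (0.40 log units; beyond the scatter), which is a readable size on this core. On the core of compound 1 the same change cannot be read, because both of its values are limits of the assay and not numbers: the limit of > 100000 nM in this assay, at which 2 of the 4 values shown sit. The series therefore shows the change at a readable size on one core only, and it does not show whether that size, or even its direction, carries from one core to the other.

From the compounds shown here alone, it remains open how a chlorine or a nitrile on that same aromatic carbon would read in this assay, since only trifluoromethyl and hydrogen appear there. Going by these compounds, it is also open whether a longer chain or a carboxylic acid in place of the chain that compound 3 and compound 4 carry would leave the size of this step as it stands.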